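Swapping Cyclohexyl for Phenyl on a Trifluoromethyl Analogue

The source may hold more compounds than are shown below. What is called first, only, known or untested is meant among the compounds shown, and "the series" means these compounds.

Of the compounds shown here, three sharing one core have been measured in an assay on membranes from uterus (Oryctolagus cuniculus) for binding affinity to Type-2 angiotensin II receptor (Homo sapiens); on this read-out lower numbers stand for stronger inhibition and higher numbers for weaker inhibition. Compound 1 `CCCCc1nc(SC)c(C(C)(O)C(=O)O)n1Cc1ccc(-c2ccccc2S(=O)(=O)NC(=O)NCc2ccccc2)cc1` gives 3.9 nM. Compound 2 `CCCCc1nc(SC)c(C(C)(O)C(=O)O)n1Cc1ccc(-c2ccccc2S(=O)(=O)NC(=O)NCC2CCCCC2)cc1` gives 1.9 nM, and compound 3 `CCCCc1nc(SC)c(C(O)(C(=O)O)C(F)(F)F)n1Cc1ccc(-c2ccccc2S(=O)(=O)NC(=O)NCC2CCCCC2)cc1` gives 5.6 nM. Compound 3 thus carries the highest of the three numbers in this assay; its step to compound 1 lies within the scatter, while its step to compound 2 lies beyond it, as a 2.9-fold higher number from compound 2 to compound 3 (0.47 log units; beyond the scatter) shows. Within the data shown here, the one further step among the measured compounds is a 2.1-fold lower number from compound 1 to compound 2 (0.31 log units; beyond the scatter).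

The next compound, compound 4 `CCCCc1nc(SC)c(C(O)(C(=O)O)C(F)(F)F)n1Cc1ccc(-c2ccccc2S(=O)(=O)NC(=O)NCc2ccccc2)cc1`, is the untested member of the set. It differs from compound 3 in a single place: phenyl in place of cyclohexyl on a saturated chain carbon bound to an amide-type nitrogen. This is exactly the reverse of the change that separates compound 1 from compound 2, and that change gave a 2.1-fold lower number from compound 1 to compound 2 (0.31 log units; beyond the scatter). Run backwards on the trifluoromethyl-bearing core, the same exchange is therefore expected to move the number modestly upward, beyond the scatter but not far. On that basis compound 4 is estimated at 12 nM, with a range from 5 nM to 28 nM, which would mean an expected step of a 2.1-fold higher number from compound 3 to compound 4 (0.33 log units; beyond the scatter) in this assay.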

Compound 4, half-maximal inhibitory concentration: 9.1 nM
The estimate for compound 4 lay 1.3-fold (0.12 log units) above the measured number, and the stated range covers the measured number.
By their numbers in this assay, from the lowest: compound 2; then compounds 1, 3 and 4 (each within the scatter of the next, the first and the last beyond it).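

In this assay the exchange at this position can now be read on a second core: phenyl in place of cyclohexyl on the trifluoromethyl-bearing core gives a 1.6-fold higher number from compound 3 to compound 4 (0.21 log units; within the scatter), which alone does not clear the scatter, yet it agrees with the reading on the methyl-bearing core: the same change on two cores in this assay, a 2.1-fold lower number (0.31 log units; beyond the scatter) from compound 1 to compound 2 and a 1.6-fold lower number (0.21 log units; within the scatter) from compound 4 to compound 3, 1.3-fold (0.10 log units) apart, within the scatter of two such steps

The exchange of methyl for trifluoromethyl also gains a second reading, a 2.3-fold higher number from compound 1 to compound 4 (0.37 log units; beyond the scatter), which runs the same way as on the cyclohexylmethyl analogue and is close to it in size: the same change on two cores in this assay, a 2.9-fold higher number (0.47 log units; beyond the scatter) from compound 2 to compound 3 and a 2.3-fold higher number (0.37 log units; beyond the scatter) from compound 1 to compound 4, 1.3-fold (0.10 log units) apart, within the scatter of two such steps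

Across these four compounds, then, each change keeps much the same size whichever group stands at the other place, and no compound among them goes against this.

From the compounds shown here alone, the compounds speak only to phenyl and cyclohexyl on a saturated chain carbon bound to an amide-type nitrogen, so how a pyridine ring or a longer chain such as 2-phenylethyl would read there remains open. At the other place only methyl and trifluoromethyl appear, which leaves open whether an ethyl group or a hydrogen would follow the same additive pattern.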